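Swapping phenyl for 3,4-dimethoxyphenyl in a flat series

The compounds below may be only part of what the source reports. "The series", "measured", "known", "first", "only" and "open" are said of these compounds alone.

In a functional assay on HepG2 cells (Homo sapiens) for inhibition, read by MTT assay, with a stated time of 24 h (a higher number here means a weaker inhibitor of growth, a lower number a stronger inhibitor of growth), compound 1 (`Cn1cc(-c2nc3ccccc3n2C(=O)c2ccccc2)c2ccccc21`) gives 42300 nM and compound 2 (`COc1ccc2c(c1)c(-c1nc3ccccc3n1C(=O)c1ccccc1)cn2C`) gives 37900 nM while compound 3 (`Cn1cc(-c2nc3ccccc3n2C(=O)c2ccccc2)c2cc(Br)ccc21`) gives 48100 nM and these three values cannot be told apart. For the measured compounds named here, compound 4 (`COc1ccc(C(=O)n2c(-c3cn(C)c4ccc(Br)cc34)nc3ccccc32)cc1OC`) keeps the core of compound 3 but has 3,4-dimethoxyphenyl in place of phenyl on a carbonyl carbon and no measured step touches that phenyl. The nearest evidence is the methoxy step (a 1.1-fold lower number from compound 1 to compound 2 (0.05 log units; within the scatter)) alongside the bromo steps (a 1.1-fold higher number from compound 1 to compound 3 (0.06 log units; within the scatter)) and (a 1.3-fold higher number from compound 2 to compound 3 (0.10 log units; within the scatter)) so no change beyond the scatter is expected. The estimated step is small (a 1.4-fold lower number from compound 3 to compound 4 (0.14 log units; within the scatter)) and only weakly supported. In this assay compound 4 is estimated at 35000 nM (expected range 14000 nM to 75000 nM).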

Compound 4, concentration for 50% growth inhibition: 9700 nM
Estimate against measurement, compound 4: 3.6-fold (0.56 log units) above, and the stated range ends above it.
By their numbers in this assay, from the lowest: compound 4; then compounds 2, 1 and 3 (each within the scatter of the next).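

The change from phenyl to 3,4-dimethoxyphenyl on the carbonyl carbon brings a 5.0-fold lower number from compound 3 to compound 4 (0.70 log units; beyond the scatter) in this assay, so this position can shift growth inhibition. For the compounds shown here, the methoxy and bromo changes elsewhere on the core all stayed within the scatter, which makes this the only step here that goes beyond it. Nothing available explains the size of this step.

As far as these compounds go, it remains open whether a single methoxy on the phenyl would be enough, and whether the same swap would work on the cores of compound 1 and compound 2. How an amine or a carboxylic acid on that phenyl would read is also unknown.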